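Pyridin-4-yl in place of pyridin-3-yl: a small expected step

The compounds below may be only part of what the source reports. "The series", "measured", "known", "first", "only" and "open" are said of these compounds alone.

Of the compounds shown here, three sharing one core have been measured in a functional assay on the whole organism for inhibition, with Cavia porcellus as the target; a higher number here means that more compound is needed for the effect, a lower number that less compound is needed. Compound 1 `COc1ccccc1OCC1SCCN1C(=O)CC(C)=O` gives 30 mg/kg, compound 2 `CCN(CC)CCNC(=O)CC(=O)N1CCSC1COc1ccccc1OC` gives 56 mg/kg, and compound 3 `COc1ccccc1OCC1SCCN1C(=O)CC(=O)NCc1cccnc1` gives 57 mg/kg. Compound 3 therefore stands within the scatter of both the others, as the two steps show: a 1.9-fold higher number from compound 1 to compound 3 (0.28 log units; within the scatter) and a 1.0-fold higher number from compound 2 to compound 3 (0.01 log units; within the scatter).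

Compound 4 `COc1ccccc1OCC1SCCN1C(=O)CC(=O)NCc1ccncc1` has not yet been measured. It carries pyridin-4-yl in place of pyridin-3-yl on a saturated chain carbon bound to an amide-type nitrogen. The same atoms are present, joined differently.

Within the data shown here, no measured step exchanges one of these pyridine groups for the other, so the evidence is indirect. The nearest step is a 1.0-fold higher number from compound 2 to compound 3 (0.01 log units; within the scatter), which replaces (diethylamino)methyl with pyridin-3-yl at this same place. The other two steps, a 1.9-fold higher number from compound 1 to compound 2 (0.27 log units; within the scatter) and a 1.9-fold higher number from compound 1 to compound 3 (0.28 log units; within the scatter), replace methyl on a carbonyl carbon with whole amine side chains, and they also stay within the scatter. Nothing in this small set favours a direction in this assay. The expected outcome is a 1.0-fold lower number from compound 3 to compound 4 (0.02 log units; within the scatter), a step no larger than the scatter. For compound 4 the estimate is 55 mg/kg, with an expected range from 25 mg/kg to 120 mg/kg.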

Compound 4, dose for half-maximal effect: 23 mg/kg
Compound 4: the middle estimate sits 2.4-fold (0.38 log units) above what was measured, and the stated range ends above it.
By their numbers in this assay, from the lowest: compounds 4, 1, 2 and 3 (each within the scatter of the next, the first and the last beyond it).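

In this assay, among these compounds, the exchange of pyridin-3-yl for pyridin-4-yl on a saturated chain carbon bound to an amide-type nitrogen is the first change at this place to pass the scatter (a 2.5-fold lower number from compound 3 to compound 4 (0.39 log units; beyond the scatter)), although both groups have the same atoms and the same counts of donors and acceptors. Among the compounds shown here, this place therefore responds to how the pyridine ring is joined, which the earlier steps did not show, and compound 4 also separates from the diethylamino side chain (a 2.4-fold lower number from compound 2 to compound 4 (0.39 log units; beyond the scatter)), while its step from the methyl group stays within the scatter (a 1.3-fold lower number from compound 1 to compound 4 (0.12 log units; within the scatter)), so the amide side chains in this set no longer read as interchangeable. The steps are modest, and nothing measured here speaks to what lies behind them.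

Going by these compounds, it remains open whether pyridin-2-yl or an unsubstituted phenyl ring at the same place would give a number closer to that of compound 3 or to that of compound 4. Also open, on these data alone, is whether a longer chain carrying pyridin-4-yl would keep the number of compound 4.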